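A Ketone-Bearing Chain Extension on a Shared Core

The source may hold more compounds than are shown below. What is called first, only, known or untested is meant among the compounds shown, and "the series" means these compounds.

The measured compounds and their values in an assay on HEK293 cells for inhibition of N-acylethanolamine-hydrolyzing acid amidase (Homo sapiens), read by fluorescence, with stated times of 10 min and 50 min (on this read-out higher numbers stand for weaker inhibition and lower numbers for stronger inhibition), are:
compound 1, `CCCON1C(=O)[C@@H](NC(=O)OCCCCC2CCCCC2)[C@@H]1C`, 133 nM
compound 2, `CCCCCON1C(=O)[C@@H](NC(=O)OCCCCC2CCCCC2)[C@@H]1C`, 387 nM
compound 3, `CCCCCCCON1C(=O)[C@@H](NC(=O)OCCCCC2CCCCC2)[C@@H]1C`, 2230 nM

Among these three, compound 1 gives the lowest number in this assay; the step of a 2.9-fold higher number from compound 1 to compound 2 (0.46 log units; beyond the scatter) and the step of a 17-fold higher number from compound 1 to compound 3 (1.22 log units; beyond the scatter) both lie beyond the scatter, so compound 1 is the strongest inhibitor of the set.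

Compound 4, `CC(=O)CCCON1C(=O)[C@@H](NC(=O)OCCCCC2CCCCC2)[C@@H]1C`, has not yet been measured. Relative to compound 1 the change is acetyl in place of hydrogen on a saturated chain carbon, three bonds along the chain from an oxygen on an unsaturated carbon.

Within the data shown here, the steps that bear on this change are those that lengthen the same chain from the same position: a 2.9-fold higher number from compound 1 to compound 2 (0.46 log units; beyond the scatter), a 17-fold higher number from compound 1 to compound 3 (1.22 log units; beyond the scatter) and, further out, a 5.8-fold higher number from compound 2 to compound 3 (0.76 log units; beyond the scatter). Each added length gave a higher number, and the added group in compound 4 lies in size between the ethyl of compound 2 and the butyl of compound 3. Among the measured compounds shown here, it carries a ketone rather than a plain chain end, and no measured compound shows what that does here.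

Compound 4 is therefore expected to give a higher number than compound 1, with a step of about a 4.5-fold higher number from compound 1 to compound 4 (0.65 log units; beyond the scatter), modest in size. Compound 4 is estimated at 600 nM, within a range of 200 nM to 1800 nM.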

Compound 4, half-maximal inhibitory concentration: 75 nM
Estimate against measurement, compound 4: 8.0-fold (0.90 log units) above; measured number outside the range, below it.
By their numbers in this assay, from the lowest: compounds 4 and 1 (each within the scatter of the next); then compound 2; then compound 3.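

The earlier compounds shown here showed only plain chains, each added length raising the number in this assay, but the acetyl breaks with that pattern: the step it brings is a 1.8-fold lower number from compound 1 to compound 4 (0.25 log units; within the scatter) and not a rise beyond the scatter. Chain size alone therefore does not set the number at this position among these compounds, for set against the plain chains the acetyl gives a 5.2-fold lower number from compound 2 to compound 4 (0.71 log units; beyond the scatter) and a 30-fold lower number from compound 3 to compound 4 (1.47 log units; beyond the scatter) even though it lies in size between the ethyl and the butyl. This saturated chain carbon thus accepts an added acetyl without the loss seen with ethyl and butyl, though nothing measured here speaks to why the ketone-bearing chain behaves differently.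

Whether the ketone itself accounts for this remains open, since no compound shown places a hydroxyl, an amine or a carboxylic acid at this chain end. Nor do the compounds shown tell whether a longer ketone-bearing chain, or a ketone moved to another carbon of the chain, would keep the number of compound 4 or follow the rise seen with the plain chains.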